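This account rests on a few compounds, and the source may have more. Where it says the series, first, only, none or still open, it means among the compounds named here.

Within the data shown here, in a functional assay on HeLa cells (Homo sapiens) for antiproliferative activity, read by MTT assay, with a stated time of 48 h (on this read-out higher numbers stand for weaker inhibition and lower numbers for stronger inhibition), compound 3 `CC[C@@H](C)[C@H](NC(=O)c1ccc(Oc2nc3ccccc3nc2NC(C)(C)C)cc1)C(=O)OC` gives 31900 nM, the only actual number so far. Compound 1 `CC[C@@H](C)[C@H](NC(=O)c1ccc(Oc2nc3ccccc3nc2C)cc1)C(=O)OC` reads > 50000 nM, which is a limit. Compound 2 `COC(=O)CNC(=O)c1ccc(Oc2nc3ccccc3nc2NC(C)(C)C)cc1` reads > 50000 nM, also a limit. The series is thus bounded by the limit of > 50000 nM in this assay, at which 2 of the 3 values shown sit.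

Compound 4 `CC(C)(C)Nc1nc2ccccc2nc1Oc1ccc(C(=O)NCC(=O)O)cc1` differs from compound 3 as follows: carboxymethyl in place of 1-(methoxycarbonyl)-2-methylbutyl on an amide-type nitrogen. In words, carboxymethyl stands in place of 1-(methoxycarbonyl)-2-methylbutyl on an amide-type nitrogen. Among the measured compounds shown here, two measured steps bear on this: an at least 1.5-fold lower number from compound 1 to compound 3 (0.19 log units; that floor lies within the scatter) and an at least 1.5-fold lower number from compound 2 to compound 3 (0.19 log units; that floor lies within the scatter). The second is the closer guide, as its sec-butyl leaves again here. From the compounds shown here alone, both are only floors, so the true size remains open.

The expected step is a 1.7-fold higher number from compound 3 to compound 4 (0.24 log units; within the scatter), towards weaker inhibition in this assay. For compound 4 the estimate is 55000 nM, with an expected range of 30000 nM to 100000 nM.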

Compound 4, half-maximal inhibitory concentration: > 50000 nM
Compound 4: no number, only a limit (the forecaster's own chance of this, stated with the estimate: 80%); the middle value is on the limit's open side.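

Carboxymethyl in place of 1-(methoxycarbonyl)-2-methylbutyl on the amide-type nitrogen gives an at least 1.5-fold higher number from compound 3 to compound 4 (0.19 log units; that floor lies within the scatter) in this assay, so the free carboxylic acid, like the glycine methyl ester of compound 2, yields no number here. The step from compound 2 to compound 4 cannot be read, as both values are limits. Compound 3 alone keeps a number at this position: the limit of > 50000 nM in this assay, at which 3 of the 4 values shown sit.

From the compounds shown here alone, how a carboxylic acid in place of the methyl ester of compound 3 would read, with sec-butyl kept, stays open. So does an amide in that place.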